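The source may report more compounds than this note shows. Statements on the series, on what has been measured and on what is new or still open speak of the compounds shown alone.

Compound 1 `Cc1ccc(Cn2cc(CSC(=S)N3CCN(C(=O)NC(C)C)CC3)nn2)cc1`: > 128000 nM
Compound 2 `COc1ccc(Cn2cc(CSC(=S)N3CCN(C(N)=O)CC3)nn2)cc1`: > 128000 nM

In a functional assay on EC9706 cells (Homo sapiens) for cytotoxicity, read by MTT assay, with a stated time of 72 h (on this read-out higher numbers stand for weaker inhibition and lower numbers for stronger inhibition), compound 1 gives no number, only a limit of the assay, > 128000 nM. Compound 2 likewise gives only a limit, > 128000 nM. Both values sit at the same limit (the limit of > 128000 nM in this assay, at which 2 of the 2 values shown sit), so the numbers shown tell nothing about whether one of these two compounds inhibits more strongly than the other. Compound 3 `COc1ccc(Cn2cc(CSC(=S)N3CCN(C(=O)NC(C)C)CC3)nn2)cc1` has not yet been measured. It differs from compound 2 in one place: isopropyl in place of hydrogen on an amide-type nitrogen. Compound 1 already carries the isopropylcarbamoyl group on the same core and stays at the limit, so no step beyond the usual scatter is expected in this assay from compound 2 to compound 3, and the step that the limit leaves unreadable from compound 2 to compound 3 is estimated as essentially none. Compound 3 is therefore expected to come out at about 200000 nM, in a range from 64000 nM to 600000 nM, most likely again reported only as a limit.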

Compound 3, half-maximal inhibitory concentration: > 128000 nM
Compound 3 gave a limit, no number (the forecaster's own chance of this, stated with the estimate: 90%); the middle value is on the limit's open side.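

Compound 3 gives > 128000 nM in this assay as a limit and not a number. No step from compound 1 or compound 2 to compound 3 can be read, since all three stop at the same limit: the limit of > 128000 nM in this assay, at which 3 of the 3 values shown sit.

The compounds shown leave open how strongly any of the three inhibits, and whether isopropyl in place of hydrogen or methoxy in place of methyl changes anything.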